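A few compounds are considered here, and "the series" means these few. Any claim that something is new, unique, unknown or untested is made for them only; others in the source may bear on it.

Measured compounds:
compound 1 `CC(CCO)n1cnc2c(Cl)nc(F)nc21` — 19800 nM
compound 2 `CC(CCO)n1cnc2c(Cl)ncnc21` — a limit, > 50000 nM
compound 3 `CCCCCCCC(CCO)n1cnc2c(N(C)C)ncnc21` — a limit, > 50000 nM

In a functional assay on HCT-116 cells (Homo sapiens) for antiproliferative activity, read by MTT assay, with a stated time of 48 h (on this read-out higher numbers stand for weaker inhibition and lower numbers for stronger inhibition), compound 1 gives 19800 nM. Compound 2 gives only a limit, > 50000 nM, so it sits at the limit of > 50000 nM in this assay, at which 2 of the 3 values shown sit. For the measured compounds named here, the one step with numbers, an at least 2.5-fold higher number from compound 1 to compound 2 (0.40 log units; beyond the scatter), concerns fluoro on an aromatic carbon and does not touch the chain. Compound 4 `OCCC(CO)n1cnc2c(Cl)ncnc21` differs from compound 2 by hydroxy in place of hydrogen on a saturated chain carbon, two bonds along the chain from an aromatic nitrogen. Going by the values given here, no measured step bears on a hydroxy added to this chain; compound 3, with its own chain and core substituent, also gives only a limit. Compound 4 is therefore expected to stay at or near the limit, with a number no higher from compound 2 to compound 4 (the limit leaves the size open) expected as no step beyond the scatter. The estimate for compound 4 is 50000 nM, range 20000 nM to 150000 nM.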

Compound 4, half-maximal inhibitory concentration: > 50000 nM
Compound 4 was reported as a limit; the forecaster's own chance of this, stated with the estimate: 70%; the middle value lies on the limit itself.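

Compound 2 and compound 4 are both reported only as limits in this assay, so no step can be read between them: the limit of > 50000 nM in this assay, at which 3 of the 4 values shown sit.

The compounds shown leave open the direction and size of any change from hydrogen to hydroxy on this chain.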